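The source may hold more compounds than are shown below. What is called first, only, known or untested is meant among the compounds shown, and "the series" means these compounds.

Two macrocycles open the series. Compound 1 `CCC[C@@H]1NC(=O)[C@@H](CO)NC(=O)[C@@H](Cc2ccc(O)cc2)NCCOc2ccccc2/C=C/CNC1=O` carries a trans double bond in its aryl-linked chain together with a hydroxymethyl side chain; in an assay on isolated protein for displacement of a labelled ligand from Motilin receptor (Homo sapiens) (a lower number here means a stronger inhibitor, a higher number a weaker inhibitor), compound 1 gives only a limit, > 10000 nM, and no number. For the measured compounds named here, compound 2 `CCC[C@@H]1NC(=O)[C@@H](C(C)C)NC(=O)[C@@H](Cc2ccc(O)cc2)NCCOc2ccccc2CCCNC1=O` has the saturated chain and an isopropyl side chain; in this assay compound 2 gives 55 nM, the only measured number in the set. The value of compound 1 sits at the limit (the limit of > 10000 nM in this assay, at which 1 of the 2 values shown sits). Going by the values given here, the two compounds differ in more than one place, so no single step between them can be read. Compound 3 `CCC[C@@H]1NC(=O)[C@@H](C(C)C)NC(=O)[C@@H](Cc2ccccc2)NCCOc2ccccc2CCCNC1=O` is compound 2 with hydrogen in place of hydroxy on an aromatic carbon, that is 4-hydroxybenzyl becoming benzyl. Among the compounds with values here, with no measured step of this kind at hand, compound 3 is expected to be somewhat weaker than compound 2, by a step estimated as a 2.7-fold higher number from compound 2 to compound 3 (0.44 log units; beyond the scatter), though a result within the scatter cannot be excluded. Compound 3 is thus estimated at 150 nM in this assay, within a range of 40 nM to 600 nM.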

Compound 3, inhibition constant: 57 nM
The estimate for compound 3 lay 2.6-fold (0.42 log units) above the measured number, and the stated range covers the measured number.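

In this assay, replacing 4-hydroxybenzyl with benzyl gives a 1.0-fold higher number from compound 2 to compound 3 (0.02 log units; within the scatter), so this pair cannot be told apart. For the compounds shown here, on this core, the hydroxy on the aromatic carbon, with its hydrogen-bond donor and acceptor, can therefore be removed without a difference beyond the scatter, which the earlier compounds could not show because they differ in more than one place. Nothing in the data shown accounts for this result.

On these data alone, it remains open whether a methoxy, a fluorine or an amine on this aromatic carbon would read the same way as hydrogen and hydroxy. Going by these compounds alone, also open is whether the trans double bond or the hydroxymethyl side chain of compound 1 goes with its limit, since no step between compound 1 and the other compounds can be read.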